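The source may hold more compounds than are shown below. What is called first, only, known or untested is meant among the compounds shown, and "the series" means these compounds.

Measured compounds in a functional assay on HeLa cells (Homo sapiens) for inhibition, read by MTT assay, with a stated time of 24 h; on this read-out lower numbers stand for stronger inhibition and higher numbers for weaker inhibition:

- compound 1 `CCOC(=O)C1=Cc2ccccc2OC1(OCc1cn(-c2ccc(C)cc2)nn1)C(F)(F)F` gives 25100 nM.
- compound 2 `CCOC(=O)C1=Cc2ccccc2OC1(OCc1cn(-c2ccccc2)nn1)C(F)(F)F` gives only a limit, > 150000 nM.
- compound 3 `CCOC(=O)C1=Cc2ccccc2OC1(OCc1cn(-c2cccc(C(F)(F)F)c2)nn1)C(F)(F)F` gives only a limit, > 150000 nM.

Compound 3 thus stands at the limit of > 150000 nM in this assay, at which 2 of the 3 values shown sit; no number for it is known, only that it lies past the limit. Among the measured compounds shown here, compound 1 is the one compound of the three with a readable value.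

Compound 4 `CCOC(=O)C1=Cc2ccccc2OC1(OCc1cn(CC(=O)NC2CCCCC2)nn1)C(F)(F)F` differs from compound 3 in one place: (cyclohexylcarbamoyl)methyl in place of 3-(trifluoromethyl)phenyl on an aromatic nitrogen.

For the measured compounds named here, no measured step exchanges a phenyl group on the aromatic nitrogen for a non-aromatic substituent, so none bears directly on this change. What is known is that changes on the aromatic nitrogen substituent shift the read-out: an at least 5.9-fold higher number from compound 1 to compound 2 (0.77 log units; beyond the scatter) and an at least 5.9-fold higher number from compound 1 to compound 3 (0.77 log units; beyond the scatter) both carry compound 1 out to the limit, while a step that the two limits leave unreadable from compound 2 to compound 3 cannot be read, both values being limits. The series therefore gives no anchor for a gain, and every substituent other than 4-methylphenyl seen so far sits at the limit.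

Compound 4 is expected to remain weak in this assay, with a fair chance of again returning only a limit; the estimate for compound 4 is 100000 nM, between 20000 nM and 300000 nM. The step from compound 3 that this estimate implies, an at least 1.5-fold lower number from compound 3 to compound 4 (0.17 log units; that floor lies within the scatter), is expected to be unreadable against the limit of compound 3.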

Compound 4, half-maximal inhibitory concentration: 11400 nM
The estimate for compound 4 lay 8.8-fold (0.94 log units) above the measured number; the measured number lies below the stated range.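

In this assay, this aromatic nitrogen proves able to carry a non-aromatic substituent with a readable result, and (cyclohexylcarbamoyl)methyl gives an at least 13-fold lower number from compound 3 to compound 4 (1.11 log units; beyond the scatter) and an at least 13-fold lower number from compound 2 to compound 4 (1.11 log units; beyond the scatter). Among the compounds shown here, the only step here with two readable values is a 2.2-fold lower number from compound 1 to compound 4 (0.34 log units; beyond the scatter), so 4-methylphenyl is no longer the only substituent on this nitrogen with a readable value, and the new group gives the lower number. Those first two steps are floors and the step between compound 2 and compound 3 cannot be read, each of these two compounds being only a limit: the limit of > 150000 nM in this assay, at which 2 of the 4 values shown sit.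

From the compounds shown here alone, what remains open is which part of the entering group matters, the carbamoyl methyl link or the cyclohexyl ring. A cyclohexyl group on the aromatic nitrogen and a (phenylcarbamoyl)methyl group would separate the two.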